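Bromo for Dimethylamino: an Expected Step to Compound 3

The source may hold more compounds than are shown below. What is called first, only, known or untested is meant among the compounds shown, and "the series" means these compounds.

Compound 1 `CCCCCCCCCCCCCCCCCCNC(=O)[C@H]1CSC(c2c[nH]c3ccccc23)N1`: 4400 nM in a functional assay on TSU-Pr1 cells for antiproliferative activity against TSU (Homo sapiens), read by sulforhodamine B assay; on this read-out higher numbers stand for weaker inhibition and lower numbers for stronger inhibition
Compound 2 `CCCCCCCCCCCCCCCCCCNC(=O)[C@H]1CSC(c2ccc(N(C)C)cc2)N1`: 3000 nM in this assay

Compound 2 sits alongside compound 1, the step of a 1.5-fold lower number from compound 1 to compound 2 (0.17 log units; within the scatter) lying within the scatter. Compound 3 `CCCCCCCCCCCCCCCCCCNC(=O)[C@H]1CSC(c2ccc(Br)cc2)N1` differs from compound 2 by bromo in place of dimethylamino on an aromatic carbon. Within the data shown here, no measured step tests this exchange; the only step known, from compound 1 to compound 2, swaps a different aromatic group and stays within the scatter, so compound 3 is expected to show no change at the digits printed from compound 2 to compound 3 (within the scatter) in this assay. Compound 3 is therefore estimated at 3000 nM, within 1200 nM to 7500 nM.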

Compound 3, half-maximal inhibitory concentration: 18300 nM
Estimate against measurement, compound 3: 6.1-fold (0.79 log units) below; measured number outside the range, above it.
By their numbers in this assay, from the lowest: compounds 2 and 1 (each within the scatter of the next); then compound 3.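

So the para substituent on this aromatic ring is not neutral in this assay: bromo in place of dimethylamino gives a clear loss (a 6.1-fold higher number from compound 2 to compound 3 (0.79 log units; beyond the scatter)), although the earlier aromatic exchange stayed within the scatter. The 4-bromophenyl compound also separates from the 1H-indol-3-yl compound (a 4.2-fold higher number from compound 1 to compound 3 (0.62 log units; beyond the scatter)). No evidence here bears on the reason for this loss.

The compounds shown leave open whether a primary amine or a methoxy group at this position would match compound 2. They also leave open whether chloro or fluoro would behave like bromo.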